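Removing the acetyl group from compound 3

This account rests on a few compounds, and the source may have more. Where it says the series, first, only, none or still open, it means among the compounds named here.

Compound 1 `COc1ccc(-c2nc(/N=C(\N)NC3CCCCC3)sc2-c2ccc(OC)cc2)cc1`: > 1000 nM, a limit
Compound 2 `COc1ccc(-c2nc(/N=C(\N)n3ccnc3)sc2-c2ccc(OC)cc2)cc1`: > 100 nM, a limit
Compound 3 `COc1ccc(-c2nc(CNC(C)=O)sc2-c2ccc(OC)cc2)cc1`: 15 nM
Compound 4 `COc1ccc(-c2nc(CN)sc2-c2ccc(OC)cc2)cc1`: not yet measured

All values come from a functional assay with Oryctolagus cuniculus as the target; on this read-out higher numbers stand for weaker inhibition and lower numbers for stronger inhibition. Among the compounds with values here, compound 3 holds the only actual number, and the other two values are limits.

The change to compound 4 is hydrogen in place of acetyl on an amine nitrogen, so that acetamidomethyl becomes aminomethyl.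

Within the data shown here, no measured step makes this exact change. The nearest evidence comes from steps that replace the whole group on the same aromatic carbon. One is an at least 66-fold lower number from compound 1 to compound 3 (1.82 log units; beyond the scatter), and the other is an at least 6.6-fold lower number from compound 2 to compound 3 (0.82 log units; beyond the scatter). The third, a step that the two limits leave unreadable from compound 1 to compound 2, adds nothing on size. These steps show that this assay can respond strongly to the group at this place, but they say nothing directly about the acetyl group. Among the measured compounds shown here, compound 3 is the only measured compound with a number rather than a limit, so any departure from it is more likely to go towards weaker inhibition. The expected change is an 8.0-fold higher number from compound 3 to compound 4 (0.90 log units; beyond the scatter), and this estimate is uncertain. For compound 4 the estimated value is 120 nM, with an expected range of 25 nM to 700 nM.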

Compound 4, half-maximal inhibitory concentration: > 100 nM
Compound 4: only a limit was reported (the forecaster's own chance of this, stated with the estimate: 25%); the middle value is on the limit's open side.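

In this assay compound 4 gives > 100 nM, which is a limit and not a number. Within the data shown here, the change on the amine nitrogen can now be read directly as an at least 6.6-fold higher number from compound 3 to compound 4 (0.82 log units; beyond the scatter), so removing the acetyl alone, with the methylene link to the aromatic carbon kept, is enough to lose the only measured potency, whereas the earlier steps replaced the whole group on that carbon. The steps from compound 1 and from compound 2 to compound 4 cannot be read, and compound 4 shares its limit with compound 2: the limit of > 100 nM in this assay, at which 2 of the 4 values shown sit.

Going by these compounds, the true size of the step stays open, as the limit fixes only its lower bound, and so does the question of whether the acetyl matters as a specific group or as any acyl on this nitrogen. A formyl, a propionyl with its longer chain or a plain methyl on the same amine nitrogen would separate these readings, since each keeps the aminomethyl frame and varies only what the nitrogen carries.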